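Changing the Benzyl Group: Expectation for Compound 3

A few compounds are considered here, and "the series" means these few. Any claim that something is new, unique, unknown or untested is made for them only; others in the source may bear on it.

Measured so far:
compound 1, `CCN(CCCOc1ccc(C(=O)/C=C/c2ccc(N(C)C)cc2)c(O)c1)Cc1ccccc1`, 13100 nM
compound 2, `CCN(CCCCCCOc1ccc(C(=O)/C=C/c2ccc(N(C)C)cc2)c(O)c1)Cc1ccc(N(C)C)cc1`, 2300 nM

In an assay on isolated protein for inhibition of Amine oxidase [flavin-containing] B (Homo sapiens) (on this read-out higher numbers stand for weaker inhibition and lower numbers for stronger inhibition), compound 2 gives 2300 nM, the lowest of the two numbers, and compound 1 gives 13100 nM, a higher number that lies beyond the usual scatter. Compound 1 and compound 2 differ in more than one place, so no single change can be credited for that gap.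

Compound 3, `CCN(CCCCCCOc1ccc(C(=O)/C=C/c2ccc(N(C)C)cc2)c(O)c1)Cc1ccccc1OC`, has not yet been measured. It differs from compound 2 in one place: 2-methoxyphenyl in place of 4-(dimethylamino)phenyl on a saturated chain carbon bound to an amine nitrogen. Among the measured compounds shown here, no measured pair shows this change on its own, so nothing within this set tells how it will read.

In this assay compound 3 is therefore estimated close to compound 2, with a small step toward a weaker value, of a size that may well fall within the scatter, a 1.7-fold higher number from compound 2 to compound 3 (0.24 log units; within the scatter). The expected value for compound 3 is 4000 nM, with a range from 1500 nM to 12000 nM.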

Compound 3, half-maximal inhibitory concentration: 700 nM
For compound 3 the middle estimate is 5.7-fold (0.76 log units) above the measured one, and the stated range ends above it.
By their numbers in this assay, from the lowest: compound 3; then compound 2; then compound 1.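

This position is not a silent one: in this assay, swapping 4-(dimethylamino)phenyl for 2-methoxyphenyl on a saturated chain carbon bound to an amine nitrogen gives a 3.3-fold lower number from compound 2 to compound 3 (0.52 log units; beyond the scatter), which means stronger inhibition. The two groups match in what was counted: each has one six-membered aromatic ring of carbon only, no hydrogen-bond donors, one hydrogen-bond acceptor and no net charge, so those counts do not separate them, even though the assay does. No measurement here explains why the swap changes the number.

The step also combines two differences, the identity of the substituent and where it sits on the ring. On these data alone, a 4-methoxyphenyl or a 2-(dimethylamino)phenyl on the same carbon would pull those two apart, and which of them matters remains open.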